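The compounds below may be only part of what the source reports. "The series", "measured", "known", "first", "only" and "open" are said of these compounds alone.

Measured compounds:
- compound 1, `CSc1cc(C)nc(SC)c1NC(=O)N(Cc1ccc(-c2cnn(C)c2)cc1)C1CCCCCC1` — > 0.1 mg/kg
- compound 2, `Cc1cc(C)c(NC(=O)N(Cc2ccc(-c3cc[nH]n3)cc2)C2CCCCCC2)c(C)c1` — > 1 mg/kg

In a functional assay on a cell-free system (plasma) with sterol O-acyltransferase, Soat (Rattus norvegicus) as the target (a lower number here means that less compound is needed, a higher number that more compound is needed for the effect), compound 1 reaches only the limit > 0.1 mg/kg, not a number (the limit of > 0.1 mg/kg in this assay, at which 1 of the 2 values shown sits). In this assay compound 2 likewise gives only the limit > 1 mg/kg, not a number (the limit of > 1 mg/kg in this assay, at which 1 of the 2 values shown sits). Among the compounds with values here, both values shown are thus limits, and no step between measured compounds is available to anchor the series.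

Compound 3, `Cc1cc(C)c(NC(=O)N(Cc2ccc(-c3cnn(C)c3)cc2)C2CCCCCC2)c(C)c1`, differs from compound 2 by 1-methyl-1H-pyrazol-4-yl in place of 1H-pyrazol-3-yl on an aromatic carbon. Compound 1 carries the same 1-methyl-1H-pyrazol-4-yl on its own core but sits at a different limit, so the two values show no usable direction for this change. Within the data shown here, with no measured step, no shift beyond the usual scatter is expected in this assay. Compound 3 is estimated at 3 mg/kg, within 1 mg/kg to 30 mg/kg. The expected step that the limit leaves unreadable from compound 2 to compound 3 is therefore small, and a further limit rather than a number is the more likely outcome.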

Compound 3, dose for half-maximal effect: 0.31 mg/kg
Compound 3: middle estimate off by 9.7-fold (0.99 log units), on the high side; the whole stated range lies above it.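

In this assay, compound 3 gives the only number among the compounds shown, and the change on an aromatic carbon para to a large group now has a direction: 1-methyl-1H-pyrazol-4-yl in place of 1H-pyrazol-3-yl gives an at least 3.2-fold lower number from compound 2 to compound 3 (0.50 log units; beyond the scatter). The size of this step is only a bound, since compound 2 stands at a limit: the limit of > 1 mg/kg in this assay, at which 1 of the 3 values shown sits. The step between the two different cores cannot be read, since compound 1 also stands at a limit: the limit of > 0.1 mg/kg in this assay, at which 1 of the 3 values shown sits.

The change removes the hydrogen-bond donor, adds the methyl and moves the attachment point all at once, and the compounds shown do not separate these; 1H-pyrazol-4-yl and 1-methyl-1H-pyrazol-3-yl would. As far as these compounds go, whether 1-methyl-1H-pyrazol-4-yl gives a number on the core of compound 1 also stays open.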